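Cytotoxicity Across Side-Chain Variants of a Shared Core

This account rests on a few compounds, and the source may have more. Where it says the series, first, only, none or still open, it means among the compounds named here.

Compound 1, `O=C1O[C@@H](CN2CCC(O)CC2)CN1c1ccc(-n2cc(-c3ccccn3)cn2)c(F)c1`: in an ADME assay on HEK293-A cells (Homo sapiens) for cytotoxicity, read by MTT assay, with a stated time of 48 h (a higher number here means a weaker inhibitor, a lower number a stronger inhibitor), compound 1 gives > 400 ug/mL, a limit of the assay rather than a number.
Compound 2, `O=C1CNC(=O)N1C[C@H]1CN(c2ccc(-n3cc(-c4ccccn4)cn3)c(F)c2)C(=O)O1`: in this assay compound 2 gives > 400 ug/mL, again a limit.
Compound 3, `CS(=O)(=O)NC[C@H]1CN(c2ccc(-n3cc(-c4ccccn4)cn3)c(F)c2)C(=O)O1`: in this assay compound 3 gives 314 ug/mL.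
Compound 4, `CCNC(=O)NC[C@H]1CN(c2ccc(-n3cc(-c4ccccn4)cn3)c(F)c2)C(=O)O1`: not yet measured in this assay.

Compound 1 stands only at a limit in this assay, and one other value shown is a limit as well, so its place among the numbers is known no closer than the limit of > 400 ug/mL in this assay, at which 2 of the 3 values shown sit. The change to compound 4 is (ethylcarbamoyl)amino in place of 4-hydroxypiperidin-1-yl on a saturated chain carbon bound to a saturated ring carbon.

Two measured steps start from compound 1 and bear on this one. The first, a step that the two limits leave unreadable from compound 1 to compound 2, cannot be read because both ends are limits. The second, an at least 1.2-fold lower number from compound 1 to compound 3 (0.10 log units; that floor lies within the scatter), is a floor that lies within the scatter. The step of an at least 1.2-fold lower number from compound 2 to compound 3 (0.10 log units; that floor lies within the scatter) is of the same kind. Nothing measured therefore points to a step beyond the scatter in either direction.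

Compound 4 is accordingly expected to sit near the limit, with an estimate of 380 ug/mL and a range from 250 ug/mL to 600 ug/mL. The step of an at least 1.0-fold lower number from compound 1 to compound 4 (0.02 log units; that floor lies within the scatter) is expected to stay within the scatter.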

Compound 4, half-maximal inhibitory concentration: 29 ug/mL
Compound 4: middle estimate off by 13-fold (1.12 log units), on the high side; the whole stated range lies above it.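

At this position, on a saturated chain carbon bound to a saturated ring carbon, the earlier compounds had shown no step beyond the scatter in this assay, whereas (ethylcarbamoyl)amino now gives an at least 13-fold lower number from compound 1 to compound 4 (1.13 log units; beyond the scatter) and an at least 13-fold lower number from compound 2 to compound 4 (1.13 log units; beyond the scatter). Compound 3 and compound 4 differ only in the group on the amine nitrogen, and ethylcarbamoyl in place of methylsulfonyl gives an 11-fold lower number from compound 3 to compound 4 (1.03 log units; beyond the scatter), so an amine nitrogen at this place does not by itself bring the number down to that of compound 4. Compound 1 and compound 2 each stand at a limit, so the steps from them are floors and their full size stays unknown: the limit of > 400 ug/mL in this assay, at which 2 of the 4 values shown sit.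

The compounds shown leave open whether the step belongs to the ethyl chain or to the carbamoyl part, which a methylcarbamoyl group, a longer chain such as propylcarbamoyl, or an acetyl group on the same amine nitrogen would help to separate. They also leave open whether a free amine at this position would fall near compound 3 or near compound 4 in this assay.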